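Compound 3 to compound 4: aryl ether to aryl sulfide

The source may hold more compounds than are shown below. What is called first, only, known or untested is meant among the compounds shown, and "the series" means these compounds.

Measured in a functional assay (aorta) with Oryctolagus cuniculus as the target; on this read-out lower numbers stand for tighter binding and higher numbers for weaker binding:
- compound 1 `COc1cc(C(C)O)ccc1OCCCN1CCC(C(c2ccc(F)cc2)c2ccc(F)cc2)CC1`: 10 nM
- compound 2 `NC(=O)c1ccc(OCCCN2CCC(C(c3ccc(F)cc3)c3ccc(F)cc3)CC2)cc1`: 31.6 nM
- compound 3 `COc1ccc(OCCCN2CCC(C(c3ccc(F)cc3)c3ccc(F)cc3)CC2)cc1`: 2.51 nM

Compound 3 has the lowest number of the three, 2.51 nM. The next structure, compound 4 `Fc1ccc(C(c2ccc(F)cc2)C2CCN(CCCSc3ccccc3)CC2)cc1`, carries phenylsulfanyl in place of 4-methoxyphenoxy on a saturated chain carbon, three bonds along the chain from an amine nitrogen in a ring.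

Among the measured compounds shown here, two measured steps bear on this place. The modest one is a 4.0-fold lower number from compound 1 to compound 3 (0.60 log units; beyond the scatter), and the large one is a 13-fold lower number from compound 2 to compound 3 (1.10 log units; beyond the scatter). Both show that the group at this end of the chain can move the number beyond the scatter. For the measured compounds named here, no measured compound carries phenylsulfanyl, so the size of this step remains poorly defined. Compound 3 already holds the lowest number, so a modest step towards a higher number is expected in this assay. The expected change is a 2.4-fold higher number from compound 3 to compound 4 (0.38 log units; beyond the scatter). For compound 4 the estimated value is 6 nM, with an expected range of 1.5 nM to 25 nM.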

Compound 4, dissociation constant: 3.16 nM
Estimate against measurement, compound 4: 1.9-fold (0.28 log units) above; the measured number falls inside the stated range.
By their numbers in this assay, from the lowest: compounds 3 and 4 (each within the scatter of the next); then compound 1; then compound 2.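

In this assay, replacing 4-methoxyphenoxy with phenylsulfanyl gives a 1.3-fold higher number from compound 3 to compound 4 (0.10 log units; within the scatter), so this position tolerates a smaller group with sulfur in place of the ether oxygen and no methoxy, with no change that can be told from the scatter. The other two steps, a 10-fold lower number from compound 2 to compound 4 (1.00 log units; beyond the scatter) and a 3.2-fold lower number from compound 1 to compound 4 (0.50 log units; beyond the scatter), are both beyond the scatter, so the phenylsulfanyl end separates from the 4-carbamoylphenoxy and 4-(1-hydroxyethyl)-2-methoxyphenoxy ends much as 4-methoxyphenoxy does. No measurement at hand explains this result.

As far as these compounds go, the swap alters the linking atom and the ring substituent together, and how plain phenoxy or 4-methoxyphenylsulfanyl would read remains open, so the two changes cannot yet be separated. Also open, from the compounds shown here alone, is how phenylsulfanyl would read on a longer chain.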